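The compounds below may be only part of what the source reports. "The series", "measured", "known", "first", "only" and "open" are said of these compounds alone.

Measured compounds in an assay on CHO cells for displacement of a labelled ligand from 5-hydroxytryptamine receptor 1D (Homo sapiens); on this read-out higher numbers stand for weaker inhibition and lower numbers for stronger inhibition:
compound 1 `c1ccc2c(c1)CCC2NC1CCN(CCCc2c[nH]c3ccc(-n4cnnc4)cc23)CC1` gives 8.9 nM
compound 2 `O=S(=O)(NCC1CCN(CCCc2c[nH]c3ccc(-n4cnnc4)cc23)CC1)c1ccccc1` gives 6.2 nM
compound 3 `CN(Cc1ccsc1)C1CCN(CCCc2c[nH]c3ccc(-n4cnnc4)cc23)CC1` gives 1.5 nM

Compound 3 has the lowest number of the three; the steps from compound 2 and from compound 1 to it, a 4.1-fold lower number from compound 2 to compound 3 (0.62 log units; beyond the scatter) and a 5.9-fold lower number from compound 1 to compound 3 (0.77 log units; beyond the scatter), are both beyond the scatter, so it is the strongest of the set in this assay.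

Compound 4 `c1ccc2c(c1)CCC2NCC1CCN(CCCc2c[nH]c3ccc(-n4cnnc4)cc23)CC1` differs from compound 3 by ((2,3-dihydro-1H-inden-1-yl)amino)methyl in place of methyl((thiophen-3-yl)methyl)amino on a saturated ring carbon. The change runs back toward compound 1 and toward the extended spacing seen in compound 2, so the relevant steps are a 5.9-fold lower number from compound 1 to compound 3 (0.77 log units; beyond the scatter) and a 4.1-fold lower number from compound 2 to compound 3 (0.62 log units; beyond the scatter), which both point to a modest rise in the number on undoing the methyl((thiophen-3-yl)methyl)amino group. Compound 4 is therefore expected to show a 5.3-fold higher number from compound 3 to compound 4 (0.73 log units; beyond the scatter), landing near compounds 1 and 2; the estimate for compound 4 is 8 nM, with a range of 3 nM to 25 nM.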

Compound 4, half-maximal inhibitory concentration: 1.1 nM
The estimate for compound 4 lay 7.3-fold (0.86 log units) above the measured number; the measured number lies below the stated range.
By their numbers in this assay, from the lowest: compounds 4 and 3 (each within the scatter of the next); then compounds 2 and 1 (each within the scatter of the next).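

On the saturated ring carbon, this assay does not separate ((2,3-dihydro-1H-inden-1-yl)amino)methyl from methyl((thiophen-3-yl)methyl)amino, with a 1.4-fold lower number from compound 3 to compound 4 (0.13 log units; within the scatter), so the low numbers do not require the thiophene ring. Extending (2,3-dihydro-1H-inden-1-yl)amino to ((2,3-dihydro-1H-inden-1-yl)amino)methyl gives an 8.1-fold lower number from compound 1 to compound 4 (0.91 log units; beyond the scatter), and on the amine nitrogen 2,3-dihydro-1H-inden-1-yl in place of phenylsulfonyl gives a 5.6-fold lower number from compound 2 to compound 4 (0.75 log units; beyond the scatter). No available data bear on the origin of these steps.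

Still open, as far as these compounds go, is whether a longer chain, such as ethyl, between the ring carbon and the amine nitrogen keeps these numbers, and whether a methyl on that nitrogen does.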